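A few compounds are considered here, and "the series" means these few. Any claim that something is new, unique, unknown or untested is made for them only; others in the source may bear on it.

Measured so far in a functional assay on MDA-MB-231 cells (Homo sapiens) for cytotoxicity, read by MTT assay, with a stated time of 48 h; a lower number here means a stronger inhibitor, a higher number a weaker inhibitor:
- compound 1 `CC(C)n1c(/C=C2/C(=O)Nc3ccc(Br)cc32)nc2ccccc21`: 3260 nM
- compound 2 `CC(C)n1c(/C=C2/C(=O)Nc3ccc(F)cc32)nc2ccccc21`: 22700 nM
- compound 3 `Cn1c(/C=C2/C(=O)Nc3ccc([N+](=O)[O-])cc32)nc2ccccc21`: "not determined" (no result reported)

Compound 3 has no standing on these numbers. No result was reported for it, so it cannot be placed against the other two. The step of interest leads from it to compound 4 `Cn1c(/C=C2/C(=O)Nc3ccc(F)cc32)nc2ccccc21`, with fluoro in place of nitro on an aromatic carbon, which is fluoro in place of nitro on an aromatic carbon.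

Among the measured compounds shown here, the only measured step in which fluoro enters is a 7.0-fold higher number from compound 1 to compound 2 (0.84 log units; beyond the scatter), where it takes the place of bromo. For the measured compounds named here, that step is modest and beyond the scatter, but nitro leaves in no measured step. It therefore gives no size or direction for the change from compound 3, and with no starting value none can be expected.

The closer guide is compound 2 (22700 nM), which carries the same fluoro group but has an isopropyl chain where compound 4 has a methyl. Going by the values given here, no measured step shows what that exchange does, so the range must stay wide.

The estimate for compound 4 is 20000 nM, with an expected range of 7000 nM to 60000 nM.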

Compound 4, half-maximal inhibitory concentration: 21700 nM
Estimate against measurement, compound 4: 1.1-fold (0.04 log units) below; the range from low to high includes it.
By their numbers in this assay, from the lowest: compound 1; then compounds 4 and 2 (each within the scatter of the next).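

In this assay, among the compounds shown here, the exchange of isopropyl for methyl on the aromatic nitrogen appears as a 1.0-fold lower number from compound 2 to compound 4 (0.02 log units; within the scatter), which gives the first reading at this nitrogen and shows that, with fluoro on the aromatic carbon, the two chains cannot be told apart in this read-out. The change from nitro to fluoro itself cannot be read, as compound 3 has no reported result, so the new value says nothing about what nitro does at this position. No measured information is available to explain why the chain exchange leaves the number within the scatter.

The compounds shown leave open whether the effect of replacing bromo with fluoro, seen as a 7.0-fold higher number from compound 1 to compound 2 (0.84 log units; beyond the scatter), also holds when methyl stands on the aromatic nitrogen, and whether the chain exchange would stay within the scatter with bromo on the aromatic carbon. From the compounds shown here alone, it also remains open how an amine or a methoxy group on that aromatic carbon, or a longer chain such as butyl on the aromatic nitrogen, would read in this assay.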